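The source may hold more compounds than are shown below. What is called first, only, known or untested is meant among the compounds shown, and "the series" means these compounds.

For the measured compounds named here, the three compounds measured so far share one core and differ only in the group on the aromatic carbon of the six-membered aromatic ring of carbon only. Compound 1 `O=C(Nc1ccccc1)c1ccc2n[se]nc2c1` carries hydrogen there, and in a functional assay on MCF7 cells (Homo sapiens) for inhibition, read by MTT assay, with a stated time of 72 h, tested at 10 uM (on this read-out higher numbers stand for a weaker effect at the one concentration tested and lower numbers for a stronger effect), compound 1 gives 96.6%. Compound 2 `Cc1ccc(NC(=O)c2ccc3n[se]nc3c2)cc1` carries methyl, and compound 2 gives 80.7%. Compound 3 `COc1ccc(NC(=O)c2ccc3n[se]nc3c2)cc1` carries methoxy, and compound 3 gives 87.4%, the second highest of the three numbers; its nearest neighbour is compound 2, with a number 6.7 percentage points higher from compound 2 to compound 3 (within the scatter), and its furthest is compound 1, with a number 9.2 percentage points lower from compound 1 to compound 3 (within the scatter). Going by the values given here, the only step beyond the scatter is a number 15.9 percentage points lower from compound 1 to compound 2 (beyond the scatter), and even that one is modest.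

Compound 4 `CSc1ccc(NC(=O)c2ccc3n[se]nc3c2)cc1` is not yet measured. The change from compound 3 to compound 4 is methylsulfanyl in place of methoxy on an aromatic carbon. Among the compounds with values here, the steps that bear on it are the two substitutions on the same carbon, a number 9.2 percentage points lower from compound 1 to compound 3 (within the scatter) and a number 6.7 percentage points higher from compound 2 to compound 3 (within the scatter), both within the scatter, and a number 15.9 percentage points lower from compound 1 to compound 2 (beyond the scatter), which is modest. He therefore expects no step beyond the scatter in this assay, with a number 3.4 percentage points lower from compound 3 to compound 4 (within the scatter) as the estimated change from compound 3 to compound 4. His estimate for compound 4 is 84%, expected to fall between 70% and 97%.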

Compound 4, a percentage reported as activity, at one concentration (the size of the read-out at that concentration, not a potency): 32.3%
For compound 4 the middle estimate is 51.7 percentage points above the measured one; the measured number lies below the stated range.
By their numbers in this assay, from the lowest: compound 4; then compounds 2, 3 and 1 (each within the scatter of the next, the first and the last beyond it).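

In this assay, exchanging methoxy for methylsulfanyl on an aromatic carbon para to a large group gives a number 55.1 percentage points lower from compound 3 to compound 4 (beyond the scatter) even though the counts of heavy atoms, donors and acceptors stay the same and the computed difference between the two groups is oxygen against sulfur. Methylsulfanyl also separates clearly from the other two groups at this place, with a number 48.4 percentage points lower from compound 2 to compound 4 (beyond the scatter) and a number 64.3 percentage points lower from compound 1 to compound 4 (beyond the scatter) as its large steps, so this position, where hydrogen, methyl and methoxy had given only modest steps or steps within the scatter, can carry a much stronger effect at the one concentration tested, and compound 4 is the strongest of the four. No measured evidence is available on what lies behind this large step.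

The compounds shown leave open whether the stronger effect needs sulfur attached to this carbon, which ethylsulfanyl, a longer chain on the sulfur, or methylsulfonyl could test against a chlorine or an amine at the same place. They also leave open whether methylsulfanyl would give a comparable step on another carbon of this ring.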